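Chloro for methyl on the core of compound 1

A few compounds are considered here, and "the series" means these few. Any claim that something is new, unique, unknown or untested is made for them only; others in the source may bear on it.

Measured so far:
- compound 1 `Cc1cc(C#N)ccc1NC(=O)c1ccc2cccnc2c1O` gives 710 nM
- compound 2 `O=C(Nc1ccc(C(F)(F)F)cc1)c1ccc(Br)cc1O` gives 360 nM

Among the measured compounds shown here, both values come from a functional assay on HL-60 cells (Homo sapiens) for cytotoxicity, read by luminescence and CellTiter-Glo, with a stated time of 3 days (on this read-out higher numbers stand for weaker inhibition and lower numbers for stronger inhibition), and are the only numbers in hand. Compound 1 at 710 nM and compound 2 at 360 nM lie within the scatter of each other, so the two cannot be ranked.

Compound 3 `N#Cc1ccc(NC(=O)c2ccc3cccnc3c2O)c(Cl)c1` keeps the core of compound 1 and carries chloro in place of methyl on an aromatic carbon, ortho to a large group and meta to a cyano group (chloro in place of methyl on an aromatic carbon). For the measured compounds named here, no two measured compounds differ in one place only, so the data give no direct measure of this swap. In this assay no step beyond the scatter is expected, and no firm direction can be stated. The estimated change is a 1.2-fold lower number from compound 1 to compound 3 (0.07 log units; within the scatter) and is expected to stay within the scatter. For compound 3 the estimated value is 600 nM with an expected range from 220 nM to 1600 nM in four of five measurements.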

Compound 3, half-maximal inhibitory concentration: 910 nM
Beside the measured number, compound 3's estimate is 1.5-fold (0.18 log units) below it; measured number inside the range.
By their numbers in this assay, from the lowest: compounds 2, 1 and 3 (each within the scatter of the next, the first and the last beyond it).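

In this assay, among the compounds shown here, chloro in place of methyl on an aromatic carbon, ortho to a large group and meta to a cyano group, gives a 1.3-fold higher number from compound 1 to compound 3 (0.11 log units; within the scatter) and provides the first direct reading of a change at this position. In this single pair, exchanging one heavy atom for another leaves the read-out within the scatter, so methyl and chloro cannot be ranked here on the core of compound 1. No measured property bears on this result, so the data give no account of it.

Going by these compounds, it remains open whether an amine, a methoxy group or a carboxylic acid at this position would give a step beyond the scatter, and whether chloro in place of methyl would read the same way on another core or with the cyano group replaced. For the compounds shown here, compound 2 differs from compound 1 and from compound 3 in more than one place, so no step to it can be read, and it adds nothing about this position.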